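A Cycloheptyl Group Meets the Assay Limit

The source may report more compounds than this note shows. Statements on the series, on what has been measured and on what is new or still open speak of the compounds shown alone.

Of the compounds shown here, three sharing one core have been measured in an ADME assay on MRC5 cells (Homo sapiens) for inhibition, with a stated time of 72 h; a lower number here means that less compound is needed, a higher number that more compound is needed for the effect. Compound 1 `COc1cccc(OC)c1C(=O)Nc1c[nH]nc1C(=O)N[C@H]1CC[C@H](O)CC1`, with 4-hydroxycyclohexyl on the amide-type nitrogen, gives 34000 nM. Compound 2 `COc1cccc(OC)c1C(=O)Nc1c[nH]nc1C(=O)NC1CCC1`, with cyclobutyl at that place, gives only a limit of > 50000 nM. Compound 3 `CCCCCNC(=O)c1n[nH]cc1NC(=O)c1c(OC)cccc1OC`, with pentyl there, likewise gives only a limit, > 50000 nM. It therefore has no exact number in this assay, and it shares its position with compound 2: the limit of > 50000 nM in this assay, at which 2 of the 3 values shown sit.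

Compound 4 `COc1cccc(OC)c1C(=O)Nc1c[nH]nc1C(=O)NC1CCCCCC1` carries cycloheptyl in place of the pentyl of compound 3 on the same amide-type nitrogen: cycloheptyl in place of pentyl on an amide-type nitrogen. Three measured steps at this nitrogen bear on the change. The exchange of cyclobutyl for pentyl shows a step that the two limits leave unreadable from compound 2 to compound 3. The two steps away from 4-hydroxycyclohexyl show an at least 1.4-fold higher number from compound 1 to compound 2 (0.16 log units; that floor lies within the scatter) and an at least 1.4-fold higher number from compound 1 to compound 3 (0.16 log units; that floor lies within the scatter), and both floors lie within the scatter. None of these steps gives a measured size for an exchange among the groups without a hydroxy substituent.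

The expected result of the change is an at least 1.1-fold lower number from compound 3 to compound 4 (0.04 log units; that floor lies within the scatter), with no step beyond the scatter anticipated. A further limit is a likely report. For compound 4, the estimated value is 45000 nM, with an expected range from 22000 nM to 90000 nM.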

Compound 4, half-maximal effective concentration: 42000 nM
Beside the measured number, compound 4's estimate is 1.1-fold (0.03 log units) above it, and the stated range covers the measured number.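

In this assay, this position now has a second exact number, and the step from the hydroxy-bearing compound reads a 1.2-fold higher number from compound 1 to compound 4 (0.09 log units; within the scatter), so cycloheptyl and 4-hydroxycyclohexyl cannot be told apart on this nitrogen. The two comparisons with the compounds that ended at a limit read an at least 1.1-fold lower number from compound 3 to compound 4 (0.07 log units; that floor lies within the scatter) and an at least 1.1-fold lower number from compound 2 to compound 4 (0.07 log units; that floor lies within the scatter); each is only a floor and lies within the scatter, so neither gives a true size for the exchange. An exact number is thus possible here without a hydroxy substituent, but compound 4 cannot be set apart from compound 2 or compound 3, whose values remain limits: the limit of > 50000 nM in this assay, at which 2 of the 4 values shown sit.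

Going by these compounds, the size of any difference between compound 2, compound 3 and compound 4 remains unknown, and the step between compound 2 and compound 3 cannot be read. Also open, on these data alone, is whether an unsubstituted cyclohexyl, a longer chain, or an amine or a carboxylic acid on the ring at this amide-type nitrogen would move the number beyond the scatter.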